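Swapping Iodo for Trifluoromethyl on Two Different Rings

This account rests on a few compounds, and the source may have more. Where it says the series, first, only, none or still open, it means among the compounds named here.

Measured compounds:
Compound 1, `NC(=O)c1c(NC(=O)c2ccccc2Cl)sc2c1CCN(C(=S)Nc1ccccc1I)C2`: 4430 nM
Compound 2, `NC(=O)c1c(NC(=O)c2ccccc2Cl)sc2c1CCN(C(=S)Nc1ccccc1C(F)(F)F)C2`: 10600 nM
Compound 3, `NC(=O)c1c(NC(=O)c2ccccc2I)sc2c1CCN(C(=S)Nc1ccccc1Cl)C2`: 8560 nM

Of the compounds shown here, three have been tested in a functional assay on HL-60 cells (Homo sapiens) for antiproliferative activity, with a stated time of 24 h; on this read-out higher numbers stand for weaker inhibition and lower numbers for stronger inhibition. Compound 1 and compound 3 are built from the same atoms joined differently; the difference between the two cores is not broken down here. Their values, 4430 nM for compound 1 and 8560 nM for compound 3, lie within the usual scatter of each other, so no order between them can be claimed.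

Within the series there is one measured step: trifluoromethyl in place of iodo on an aromatic carbon. It gives a 2.4-fold higher number from compound 1 to compound 2 (0.38 log units; beyond the scatter).

Compound 4, `NC(=O)c1c(NC(=O)c2ccccc2C(F)(F)F)sc2c1CCN(C(=S)Nc1ccccc1Cl)C2`, has not yet been measured in this assay. It differs from compound 3 by trifluoromethyl in place of iodo on an aromatic carbon, the same change as from compound 1 to compound 2, on a place described in the same words. Resting on compound 1 and compound 2 alone, the step from compound 3 to compound 4 is expected to be a 2.1-fold higher number from compound 3 to compound 4 (0.32 log units; beyond the scatter). For compound 4 the estimate in this assay is 18000 nM, with a range from 8000 nM to 45000 nM.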

Compound 4, half-maximal inhibitory concentration: 17600 nM
Compound 4: the middle estimate sits 1.0-fold (0.01 log units) above what was measured; the measured number falls inside the stated range.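

In this assay, trifluoromethyl in place of iodo gives a 2.1-fold higher number from compound 3 to compound 4 (0.31 log units; beyond the scatter), and this step stands close to the one seen earlier on the other core: the same change on two cores in this assay, a 2.4-fold higher number (0.38 log units; beyond the scatter) from compound 1 to compound 2 and a 2.1-fold higher number (0.31 log units; beyond the scatter) from compound 3 to compound 4, 1.2-fold (0.07 log units) apart, within the scatter of two such steps. In these two pairs, then, the change carried over from one core to the other, with both steps pointing towards a higher number and the gap between their sizes lying within the scatter. This does not show that the step would keep its size on any further core, since it rests on two pairs only, and the numbers alone give no reason why the change acts as it does.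

The compounds shown leave open how other groups would behave where iodo and trifluoromethyl sit, such as a nitrile, a methoxy group or an amine. They also leave open what would happen if the 2-iodophenyl and 2-(trifluoromethyl)phenyl groups were exchanged for a plain phenyl.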